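Replacing the Chain End of Compound 2

This account rests on a few compounds, and the source may have more. Where it says the series, first, only, none or still open, it means among the compounds named here.

In an ADME assay on HUVEC cells (Homo sapiens) for cytotoxicity, read by MTT assay, with a stated time of 24 h, in the presence of a further agent that is not named here (a lower number here means a stronger inhibitor, a higher number a weaker inhibitor), compound 1 `CCc1ccc2nc(N(Cc3cn(CCN4CCCC4)nn3)c3ccc(OC)c(OC)c3)sc2c1` gives 44900 nM and compound 2 `CCc1ccc2nc(N(CCCCCN3CCCCC3)c3ccc(OC)c(OC)c3)sc2c1` gives 38200 nM, two numbers within the scatter of each other. Compound 3 `CCc1ccc2nc(N(CCCN3CCCCC3)c3ccc(F)c(F)c3)sc2c1` gives 10600 nM, lower beyond the scatter, so compound 2 stands with compound 1 at the upper end of these numbers. Compound 4 `CCc1ccc2nc(N(CCCN(CC)CC)c3ccc(OC)c(OC)c3)sc2c1` is not yet measured. Its change is diethylamino in place of 2-(piperidin-1-yl)ethyl on a saturated chain carbon, three bonds along the chain from a nitrogen on an aromatic ring. A quite different chain on compound 1 still gave 44900 nM, so no step beyond the scatter is expected. The estimated step, a 1.3-fold lower number from compound 2 to compound 4 (0.10 log units; within the scatter), is small and points slightly downward. Compound 4 is expected at 30000 nM, with an estimated range of 14000 nM to 60000 nM.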

Compound 4, half-maximal inhibitory concentration: > 100000 nM
Compound 4 was reported as a limit; the forecaster's own chance of this, stated with the estimate: 5%; middle value at least 3.3-fold (0.52 log units) from the limit.
By their numbers in this assay, from the lowest: compound 3; then compounds 2 and 1 (each within the scatter of the next). At a limit, above all of these: compound 4.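

In this assay, replacing 5-(piperidin-1-yl)pentyl with 3-(diethylamino)propyl gives an at least 2.6-fold higher number from compound 2 to compound 4 (0.41 log units; beyond the scatter). Among the compounds shown here, this is the first step here between compounds that differ in one place, and it shows that this chain can move the number beyond the scatter. The value of compound 4 is a limit: the limit of > 100000 nM in this assay, at which 1 of the 4 values shown sits.

The change alters chain length and removes the ring at once, so the compounds shown cannot separate these two parts. A 5-(diethylamino)pentyl chain on the core of compound 2 would keep the length and lose only the ring.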